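The source may report more compounds than this note shows. Statements on the series, on what has been measured and on what is new or still open speak of the compounds shown alone.

Compound 1, `COc1ccc2nc(C)cc(OCC(=O)Nc3ccccc3)c2c1`, gives 39800 nM in a toxicity assay on HepG2 cells (Homo sapiens) for inhibition, read by CellTiter-Glo, with a stated time of 48 h; a higher number here means a weaker inhibitor, a lower number a stronger inhibitor.
Compound 2, `COc1ccc(NC(=O)COc2cc(C)nc3ccc(OC)cc23)cc1`, reaches only the assay's limit, > 100000 nM.
Compound 3, `COc1ccc2nc(C)cc(OCC(=O)Nc3cccnc3)c2c1`, likewise reaches only the limit, > 100000 nM.

Compound 3 thus stands at the limit of > 100000 nM in this assay, at which 2 of the 3 values shown sit, with no number of its own. The two readable steps, an at least 2.5-fold higher number from compound 1 to compound 2 (0.40 log units; beyond the scatter) and an at least 2.5-fold higher number from compound 1 to compound 3 (0.40 log units; beyond the scatter), both move toward that limit, while a step that the two limits leave unreadable from compound 2 to compound 3 cannot be sized. Compound 4, `COc1ccc2nc(C)cc(OCC(=O)Nc3ccncn3)c2c1`, differs from compound 3 by pyrimidin-4-yl in place of pyridin-3-yl on an amide-type nitrogen. Within the data shown here, no measured step swaps a pyridin-3-yl for a pyrimidin-4-yl, so the nearest guide is that an at least 2.5-fold higher number from compound 1 to compound 3 (0.40 log units; beyond the scatter) already ran to the limit. Compound 4 is therefore expected to sit at the limit as well, around 100000 nM with a range from 40000 nM to 300000 nM, which amounts to the expected step of a number no higher from compound 3 to compound 4 (the limit leaves the size open).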

Compound 4, half-maximal inhibitory concentration: > 100000 nM
Compound 4: a limit, no number (the forecaster's own chance of this, stated with the estimate: 70%); the middle value sits exactly at the limit.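

With pyrimidin-4-yl in place of phenyl on the amide-type nitrogen, the result is an at least 2.5-fold higher number from compound 1 to compound 4 (0.40 log units; beyond the scatter), so a ring with 2 hetero atoms ends at the limit just as pyridin-3-yl does. Compound 4 adds a further group at this place that gives no number in this assay, only a limit: the limit of > 100000 nM in this assay, at which 3 of the 4 values shown sit.

The steps among compound 2, compound 3 and compound 4 cannot be read, and these three stay unranked. Among the compounds shown, only the phenyl of compound 1 gives a number, so it remains open whether a chlorine or an amine on that phenyl would keep a measurable value.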